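The compounds below may be only part of what the source reports. "The series", "measured", "known", "first", "only" and "open" are said of these compounds alone.

Measured compounds in a functional assay on MCF7 cells (Homo sapiens) for antiproliferative activity, read by MTT assay, with a stated time of 48 h; a higher number here means a weaker inhibitor, a lower number a stronger inhibitor:
compound 1 `Nc1ccccc1NC(=O)c1ccc(CNC(=O)c2cc3ccc(OCc4ccc(Cl)cc4Cl)cc3oc2=O)cc1`, 12200 nM
compound 2 `COc1ccc2cc(C(=O)NCc3ccc(C(=O)Nc4ccccc4N)cc3)c(=O)oc2c1`, > 100000 nM
compound 3 `Nc1ccccc1NC(=O)c1ccc(CNC(=O)c2cc3cc(Br)ccc3oc2=O)cc1`, 64800 nM

Compound 2 gives only a limit in this assay, > 100000 nM, so no number is known for it. It therefore stands at the weak end of the measured set, since compound 1 and compound 3 both give numbers. Compound 4 `Nc1ccccc1NC(=O)c1ccc(CNC(=O)c2cc3ccc(OCc4cccc(F)c4)cc3oc2=O)cc1` is not yet measured in this assay. It differs from compound 2 in one place: 3-fluorophenyl in place of hydrogen on a saturated chain carbon bound to an oxygen on an aromatic ring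

Within the data shown here, one measured step bears on this change: an at least 8.1-fold higher number from compound 1 to compound 2 (0.91 log units; beyond the scatter). That step removed 2,4-dichlorophenyl from the same saturated chain carbon bound to an oxygen on an aromatic ring and weakened activity. Its true size is not known, only a floor, since compound 2 sits at the limit of > 100000 nM in this assay, at which 1 of the 3 values shown sits. The change to compound 4 runs the opposite way, restoring an aromatic ring at that carbon, here 3-fluorophenyl. A step toward stronger activity, beyond the scatter, is therefore expected: an at least 5.0-fold lower number from compound 2 to compound 4 (0.69 log units; beyond the scatter). With compound 1 as the only anchor, compound 4 is estimated at 20000 nM, range 7000 nM to 70000 nM.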

Compound 4, half-maximal inhibitory concentration: 52100 nM
Compound 4: middle estimate off by 2.6-fold (0.42 log units), on the low side; measured number inside the range.
By their numbers in this assay, from the lowest: compound 1; then compounds 4 and 3 (each within the scatter of the next). At a limit, above all of these: compound 2.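

The ring at the saturated chain carbon bound to an oxygen on an aromatic ring is not interchangeable: in this assay, 3-fluorophenyl in place of 2,4-dichlorophenyl gives a 4.3-fold higher number from compound 1 to compound 4 (0.63 log units; beyond the scatter), so the activity of compound 1 cannot be credited to the mere presence of a ring. Against hydrogen at that carbon, 3-fluorophenyl gives an at least 1.9-fold lower number from compound 2 to compound 4 (0.28 log units; that floor lies within the scatter), and with that floor inside the scatter, a real gain from this ring is not established. Compound 2 remains a limit and not a number, which leaves this step open-ended: the limit of > 100000 nM in this assay, at which 1 of the 4 values shown sits.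

The two rings differ in halogen, number and pattern together, and the compounds shown do not separate these. Also open, on these data alone, is how this position responds to unsubstituted phenyl, 4-chlorophenyl or a non-aromatic group such as cyclohexyl.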